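Swapping the aryl group on a shared core

This account rests on a few compounds, and the source may have more. Where it says the series, first, only, none or still open, it means among the compounds named here.

compound 1 `COc1ccc(-c2cc(-c3cc(C(C)C)c(O)cc3C)[nH]c(=O)c2C#N)cc1`: 35%
compound 2 `COc1ccc(-c2cc(-c3cc(C(C)C)c(O)cc3C)[nH]c(=O)c2C#N)cc1OC`: 44%

In a functional assay for inhibition, tested at 40 ug/mL (a higher number here means a stronger effect of the compound at the concentration tested, a lower number a weaker effect), compound 2 gives 44%, the top of the two numbers but within the scatter of compound 1, which gives 35%. Compound 3 `Cc1cc(O)c(C(C)C)cc1-c1cc(-c2ccccc2Cl)c(C#N)c(=O)[nH]1` differs from compound 2 by 2-chlorophenyl in place of 3,4-dimethoxyphenyl on an aromatic carbon. Among the measured compounds shown here, the only measured step on this part of the molecule is a number 9 percentage points higher from compound 1 to compound 2 (within the scatter), and no measured step removes both methoxy groups or brings in chlorine. Compound 3 is therefore expected to stay close, with a step of a number 6 percentage points lower from compound 2 to compound 3 (within the scatter). Compound 3 is estimated at 38%, between 18% and 58%.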

Compound 3, a percentage reported as inhibition, at one concentration (the size of the read-out at that concentration, not a potency): 20%
For compound 3 the middle estimate is 18 percentage points above the measured one; the range from low to high includes it.
By their numbers in this assay, from the lowest: compound 3; then compounds 1 and 2 (each within the scatter of the next).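

Until now this position, opposite the ring nitrogen, had shown only a step within the scatter; with 2-chlorophenyl, the aryl group makes a difference that can be read in this assay (a number 24 percentage points lower from compound 2 to compound 3 (beyond the scatter)). The fall also holds against the 4-methoxyphenyl of compound 1 (a number 15 percentage points lower from compound 1 to compound 3 (beyond the scatter)), so compound 3 lies beyond the scatter of both methoxy-bearing compounds. No evidence on the reason for this fall is at hand.

From the compounds shown here alone, whether it follows from the chlorine, its place in 2-chlorophenyl, or the loss of methoxy remains open. Going by these compounds, how an aryl group carrying an amine or a carboxylic acid would read here is also open.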